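Anilino in place of 2-aminophenyl: an expected step

The compounds below may be only part of what the source reports. "The series", "measured", "known", "first", "only" and "open" are said of these compounds alone.

Measured in a functional assay, read by spectrophotometry, with a stated time of 5 min; on this read-out higher numbers stand for weaker inhibition and lower numbers for stronger inhibition:
- compound 1 `Nc1ccccc1/N=C\c1cc(=O)oc2cc(OCc3ccccc3)cc(OCc3ccccc3)c12`: 258000 nM
- compound 2 `Nc1ccccc1/N=C\c1cc(=O)oc2cc(OCc3ccccc3)ccc12`: 217000 nM
- compound 3 `N/N=C\c1cc(=O)oc2cc(OCc3ccccc3)cc(OCc3ccccc3)c12`: 36500 nM

Compound 2 stands in the upper part of this small set: the step of a 1.2-fold lower number from compound 1 to compound 2 (0.08 log units; within the scatter) lies within the scatter, while compound 3 gives a clearly lower number. Compound 4 `O=c1cc(/C=N\Nc2ccccc2)c2ccc(OCc3ccccc3)cc2o1` differs from compound 2 thus: anilino in place of 2-aminophenyl on a double-bonded nitrogen. In words, anilino replaces 2-aminophenyl on a double-bonded nitrogen. Among the measured compounds shown here, the closest precedent is amino for 2-aminophenyl at that place, the modest step of a 7.1-fold lower number from compound 1 to compound 3 (0.85 log units; beyond the scatter), which lies beyond the scatter. For the measured compounds named here, no measured compound carries anilino, so only part of that step is assumed. A lower number is expected in this assay, an estimated 3.1-fold lower number from compound 2 to compound 4 (0.49 log units; beyond the scatter). For compound 4 the estimated value is 70000 nM, with an expected range from 25000 nM to 200000 nM.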

Compound 4, half-maximal inhibitory concentration: 416000 nM
Estimate against measurement, compound 4: 5.9-fold (0.77 log units) below, and the stated range ends below it.
By their numbers in this assay, from the lowest: compound 3; then compounds 2, 1 and 4 (each within the scatter of the next).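

In this assay anilino in place of 2-aminophenyl on a double-bonded nitrogen gives a 1.9-fold higher number from compound 2 to compound 4 (0.28 log units; within the scatter), so this assay does not separate the two groups. The lower number seen with amino at that place, a 7.1-fold lower number from compound 1 to compound 3 (0.85 log units; beyond the scatter), thus does not carry over to anilino, and the two larger groups stay together at the high end of the set. Nothing available explains this result.

Going by these compounds, it remains open whether amino gives the same step on the core of compound 2, which carries one benzyloxy group. On these data alone, it is also open whether methylamino at that place would behave like amino or like anilino.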